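Azole exchange on the aryl urea series

The source may hold more compounds than are shown below. What is called first, only, known or untested is meant among the compounds shown, and "the series" means these compounds.

Among the compounds with values here, compound 2 `Cc1cc(C)c(NC(=O)N(Cc2ccc(-c3cnn(C)c3)cc2)C2CCCCCC2)c(C)c1` carries the 1-methyl-1H-pyrazol-4-yl group and is the one member with a measured number: in a functional assay on a cell-free system (plasma) with sterol O-acyltransferase, Soat (Rattus norvegicus) as the target (on this read-out higher numbers stand for an effect only at larger amounts of compound and lower numbers for an effect already at smaller amounts), compound 2 gives 0.31 mg/kg. Compound 1 `Cc1cc(C)c(NC(=O)N(Cc2ccc(-n3cccn3)cc2)C2CCCCCC2)c(C)c1` reaches only a limit in this assay, > 1 mg/kg. Within the data shown here, the single measured step, an at least 3.2-fold lower number from compound 1 to compound 2 (0.50 log units; beyond the scatter), cannot be sized more closely because the limit of > 1 mg/kg in this assay, at which 1 of the 2 values shown sits, caps what compound 1 shows. Compound 3 `Cc1cc(C)c(NC(=O)N(Cc2ccc(-n3ccnn3)cc2)C2CCCCCC2)c(C)c1` is the next member; its change from compound 2 is 1H-1,2,3-triazol-1-yl in place of 1-methyl-1H-pyrazol-4-yl on an aromatic carbon. Among the measured compounds shown here, the entering group is, like the group in compound 1, a five-membered azole joined through a ring nitrogen, so the only step that bears on the change is the one from compound 1 to compound 2, which the new change partly reverses. In this assay the step expected is a 2.6-fold higher number from compound 2 to compound 3 (0.41 log units; beyond the scatter), back toward the limit. Compound 3 is estimated at 0.8 mg/kg, within 0.3 mg/kg to 3 mg/kg, with a real chance that only a limit is reported.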

Compound 3, dose for half-maximal effect: > 1 mg/kg
Compound 3: only a limit was reported; the forecaster's own chance of this, stated with the estimate: 45%; middle value at least 1.2-fold (0.09 log units) from the limit.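

In this assay compound 3 gives > 1 mg/kg, which is a limit and not a number. With 1H-1,2,3-triazol-1-yl in place of 1-methyl-1H-pyrazol-4-yl on the aromatic carbon para to a large group, the series shows an at least 3.2-fold higher number from compound 2 to compound 3 (0.50 log units; beyond the scatter); among the three compounds shown, the two azoles joined through a ring nitrogen both end at the limit, and only compound 2, with its azole joined through a ring carbon, gives a number, with no compound here going against this. Compound 1 and compound 3 cannot be compared with each other, and neither step from compound 2 can be sized more closely, because the values end at a limit: the limit of > 1 mg/kg in this assay, at which 2 of the 3 values shown sit.

The compounds shown change the point of attachment, the ring nitrogen count and the methyl group together, so it stays open which of these carries the step. An unsubstituted 1H-pyrazol-4-yl group would address the methyl group, and a 1-methyl-1H-1,2,3-triazol-4-yl group would address the third ring nitrogen with the attachment through carbon kept.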